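The source may hold more compounds than are shown below. What is called first, only, known or untested is meant among the compounds shown, and "the series" means these compounds.

Measured compounds:
- compound 1, `O=C(CN1CCC(Cc2ccccc2)CC1)Nc1ccc(C(=O)/C=C/c2cn(Cc3ccc(Br)cc3)nn2)cc1`: 41900 nM
- compound 2, `CCCCCCCCCCn1cc(/C=C/C(=O)c2ccc(NC(=O)CN3CCN(c4ccccc4)CC3)cc2)nn1`: 59100 nM
- compound 3, `CCCCCCCCn1cc(/C=C/C(=O)c2ccc(NC(=O)CN3CCN(c4ccccc4OC)CC3)cc2)nn1`: 26800 nM

All three compounds were tested in a functional assay on HeLa cells (Homo sapiens) for inhibition, read by MTT assay; on this read-out lower numbers stand for stronger inhibition and higher numbers for weaker inhibition. Compound 1 gives 41900 nM in this assay. Compound 2 gives 59100 nM, and compound 3 gives 26800 nM. The gap from compound 1 to compound 2 and the gap from compound 1 to compound 3 both fall within the usual scatter of this kind of measurement, so the three numbers cannot be told apart with confidence; all three describe weak inhibition.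

Compound 4, `CCCCCCCCn1cc(/C=C/C(=O)c2ccc(NC(=O)CN3CCC(Cc4ccccc4)CC3)cc2)nn1`, has not yet been measured. Its structure follows from compound 1 by one change: heptyl in place of 4-bromophenyl on a saturated chain carbon bound to an aromatic nitrogen. The remainder of compound 1, including the amide link and the benzylpiperidine, is kept. Among the compounds with values here, no measured pair shows this exact change in isolation, so nothing can be drawn from a recorded step. What can be said is that compound 2 and compound 3, which carry long alkyl chains on the same aromatic nitrogen, give numbers within the scatter of compound 1. On this basis the step of a 1.1-fold lower number from compound 1 to compound 4 (0.04 log units; within the scatter) is expected to stay within the scatter, with no clear direction. Compound 4 is expected to give 38000 nM, in a range from 13000 nM to 110000 nM.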

Compound 4, half-maximal inhibitory concentration: 78600 nM
Estimate against measurement, compound 4: 2.1-fold (0.32 log units) below; the measured number falls inside the stated range.
By their numbers in this assay, from the lowest: compounds 3, 1, 2 and 4 (each within the scatter of the next, the first and the last beyond it).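

In this assay, within the data shown here, the exchange of 4-bromophenyl for heptyl on a saturated chain carbon bound to an aromatic nitrogen gives a 1.9-fold higher number from compound 1 to compound 4 (0.27 log units; within the scatter), the first reading of a single change at this position, since compound 2 and compound 3 differ from compound 1 in more than one place. Read one bond further out, as 4-bromobenzyl to octyl, the change removes the aromatic ring and the bromine, yet the two numbers cannot be told apart, so with the amide link and the benzylpiperidine kept, the ring-bearing group and the open chain are not distinguished by this read-out. Nothing at hand offers an explanation for this result or bears on it beyond the cell read-out itself.

Going by these compounds, whether an unsubstituted benzyl, a longer chain or a chain ending in an amine or a carboxylic acid at this position would move the number beyond the scatter of compound 1 remains open. On these data alone, it is also open whether this single step would read the same with a different group in place of the benzylpiperidine.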